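The source may hold more compounds than are shown below. What is called first, only, known or untested is meant among the compounds shown, and "the series" means these compounds.

Notes on the series. Compound 1 `CCn1ccnc1-c1cc(OC)c(OC)c(OC)c1` is measured in a functional assay on MDA-MB-468 cells (Homo sapiens) for antiproliferative activity, read by MTT assay, with a stated time of 72 h; a lower number here means a stronger inhibitor, a higher number a weaker inhibitor; here compound 1 gives only the assay limit > 100000 nM. Compound 2 `COc1cc(-c2nccn2C(C)C)cc(OC)c1OC` likewise gives only the limit > 100000 nM in this assay. Compound 3 `COc1cc(-c2nccn2S(=O)(=O)c2ccccc2)cc(OC)c1OC` also sits at the limit > 100000 nM. Among the compounds with values here, the one single-site step, a step that the two limits leave unreadable from compound 1 to compound 2, is unreadable because of the limit of > 100000 nM in this assay, at which 3 of the 3 values shown sit. Compound 4 `COc1cccc(-n2ccnc2-c2cc(OC)c(OC)c(OC)c2)c1` differs from compound 1 by 3-methoxyphenyl in place of ethyl on an aromatic nitrogen. Within the data shown here, no measured step covers this change, and the three measured compounds give no readable number at all. The expectation for compound 4 is therefore loose, with a fair chance that this assay again returns only a limit. The expected step of an at least 1.6-fold lower number from compound 1 to compound 4 (0.22 log units; that floor lies within the scatter) is set as an estimate only. Compound 4 is expected at 60000 nM, within 5000 nM to 300000 nM.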

Compound 4, half-maximal inhibitory concentration: 10400 nM
The estimate for compound 4 lay 5.8-fold (0.76 log units) above the measured number; the measured number falls inside the stated range.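

Notes on the result. A readable number now appears in this assay at this aromatic nitrogen, where the two small alkyl groups gave none: the change to 3-methoxyphenyl gives an at least 9.6-fold lower number from compound 1 to compound 4 (0.98 log units; beyond the scatter) and also an at least 9.6-fold lower number from compound 2 to compound 4 (0.98 log units; beyond the scatter) for the same exchange from isopropyl. Both steps are floors only, because compound 1 and compound 2 each sit at a limit: (the limit of > 100000 nM in this assay, at which 3 of the 4 values shown sit). As far as these compounds go, it remains open whether the methoxy group or the ring itself carries the step, and whether an unsubstituted phenyl or a benzyl group on this nitrogen would give a comparable number.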